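Trading Tert-Butyl for Cyclohexyl on an Amide Nitrogen

The source may report more compounds than this note shows. Statements on the series, on what has been measured and on what is new or still open speak of the compounds shown alone.

Three compounds share one core and differ only in what sits on the amide-type nitrogen. Compound 1 `CCNC(=O)CC1CCc2cc(OC)c(OC)cc21` carries a hydrogen and an ethyl there; in a functional assay on the whole organism (strain Wistar) for inhibition, with Rattus norvegicus as the target, read by paw edema, with stated times of 60 min and 4 h, at a dose of 100 mg/kg by the oral route (on this read-out lower numbers stand for less inhibition and higher numbers for more inhibition at the one dose given (going by the name of the read-out)), compound 1 gives 26.6%. Compound 2 `CCN(CC)C(=O)CC1CCc2cc(OC)c(OC)cc21` carries two ethyl groups, and compound 2 gives 37.5%. Compound 3 `COc1cc2c(cc1OC)C(CC(=O)NC(C)(C)C)CC2` carries a tert-butyl, and compound 3 gives 32.8%. Compound 3 thus stands second highest of the three, yet its gaps to both neighbours are small: a number 4.7 percentage points lower from compound 2 to compound 3 (within the scatter), and a number 6.2 percentage points higher from compound 1 to compound 3 (within the scatter). Going by the values given here, only one step among the three stands out, a number 10.9 percentage points higher from compound 1 to compound 2 (beyond the scatter).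

Compound 4 `COc1cc2c(cc1OC)C(CC(=O)NC1CCCCC1)CC2` is the next move from compound 3: cyclohexyl in place of tert-butyl on an amide-type nitrogen. Both groups are attached to the amide-type nitrogen whose other neighbour is the carbonyl carbon. The steps bearing on this change are the ones that altered the group on that nitrogen, and only the addition of a second ethyl in compound 2 moved the number beyond the scatter, while exchanging ethyl for tert-butyl did not. No step beyond the scatter is therefore expected here, and compound 4 is expected to show a number 2.2 percentage points higher from compound 3 to compound 4 (within the scatter). The estimate for compound 4 is 35%, with a range from 22% to 48%.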

Compound 4, a percentage reported as inhibition, in the whole organism at one dose (the size of the read-out at that dose, not a potency): 50%
For compound 4 the middle estimate is 15 percentage points below the measured one; measured number outside the range, above it.
By their numbers in this assay, from the lowest: compounds 1, 3 and 2 (each within the scatter of the next, the first and the last beyond it); then compound 4.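

In this assay, the group on the amide-type nitrogen can shift the number much further than the earlier exchange of ethyl for tert-butyl did: cyclohexyl in place of tert-butyl gives a number 17.2 percentage points higher from compound 3 to compound 4 (beyond the scatter), although neither group has hydrogen-bond donors, hydrogen-bond acceptors or a net charge. Compound 4 also stands clear of the other two, with a number 12.5 percentage points higher from compound 2 to compound 4 (beyond the scatter) and a number 23.4 percentage points higher from compound 1 to compound 4 (beyond the scatter), and it keeps the amide hydrogen, as compound 1 and compound 3 do, so replacing that hydrogen, as in compound 2, is not required for the highest number among these four. Nothing measured here shows what lies behind this step.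

Cyclohexyl differs from tert-butyl both by being a ring and in its count of carbons, so the compounds shown cannot separate these two differences. A cyclopentyl, a phenyl or an open-chain hexyl on the same nitrogen would help to tell them apart, and since every reading comes from one dose, none of them gives a potency.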